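The source may report more compounds than this note shows. Statements on the series, on what has been measured and on what is new or still open speak of the compounds shown alone.

Measured so far:
Compound 1 `N#CC1=C(N)Oc2c(c3nc4ccccc4nc3c3ccccc23)C12C(=O)N(Cc1cnnn1-c1cccc(Cl)c1)c1ccccc12` gives 43600 nM in a functional assay on MCF7 cells (Homo sapiens) for antiproliferative activity, read by MTT assay, with a stated time of 48 h; a lower number here means a stronger inhibitor, a higher number a weaker inhibitor.
Compound 2 `CCOc1ccc(-n2nncc2CN2C(=O)C3(C(C#N)=C(N)Oc4c3c3nc5ccccc5nc3c3ccccc43)c3ccccc32)cc1` gives > 50000 nM in this assay, a limit of the assay and not a number.
Compound 3 `Cc1ccc(-n2nncc2CN2C(=O)C3(C(C#N)=C(N)Oc4c(N)cc5nc6ccccc6nc5c43)c3ccccc32)cc1C` gives > 50000 nM in this assay, again a limit and not a number.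

Compound 3 therefore stands at the limit of > 50000 nM in this assay, at which 2 of the 3 values shown sit. The unmeasured compound 4 `N#CC1=C(N)Oc2c(N)cc3nc4ccccc4nc3c2C12C(=O)N(Cc1cnnn1-c1c(Cl)cc(Cl)cc1Cl)c1ccccc12` differs from it by 2,4,6-trichlorophenyl in place of 3,4-dimethylphenyl on an aromatic nitrogen. Going by the values given here, the only measured step at that aromatic nitrogen is an at least 1.1-fold higher number from compound 1 to compound 2 (0.05 log units; that floor lies within the scatter), which shows a different aryl there moving the number, if at all, only as far as the limit. On this basis no shift beyond the scatter is expected, and another limit is the likeliest outcome. Compound 4 is estimated to give 60000 nM, within 20000 nM to 150000 nM. That estimate means an expected step that the limit leaves unreadable from compound 3 to compound 4.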

Compound 4, half-maximal inhibitory concentration: 37800 nM
Compound 4: the middle estimate sits 1.6-fold (0.20 log units) above what was measured, within the range that was stated.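

In this assay, 2,4,6-trichlorophenyl in place of 3,4-dimethylphenyl on the aromatic nitrogen gives an at least 1.3-fold lower number from compound 3 to compound 4 (0.12 log units; that floor lies within the scatter). This shows that an aryl change at this nitrogen can yield a readable number on the core of compound 3, whereas the earlier step there involved a different core. Compound 3 holds only a limit, so the true size of the step stays unread, and values at the limit remain common: the limit of > 50000 nM in this assay, at which 2 of the 4 values shown sit.

Still open, as far as these compounds go, is whether a 3-chlorophenyl group on this core would also give a readable number. Also open, from the compounds shown here alone, is whether an aryl ring bearing an amine or a carboxylic acid would move the number beyond the scatter.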